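The source may hold more compounds than are shown below. What is called first, only, known or untested is meant among the compounds shown, and "the series" means these compounds.

Compound 1 `O=C1COCCN1c1ccc(/N=C\c2c[nH]c3ccccc23)cc1` gives 101% in an ADME assay on BV-2 cells (Mus musculus) for cytotoxicity, read by MTT assay, with a stated time of 48 h, tested at 100 uM; a lower number here means a stronger effect, a higher number a weaker effect of the compound at the concentration tested. Compound 2 `Cc1ccc(S(=O)(=O)n2cc(/C=N\c3ccc(N4CCOCC4=O)cc3)c3ccccc32)cc1` gives 57.4% in this assay.

Among the measured compounds shown here, compound 2 stands lowest of the two numbers; its only neighbour, compound 1, sits higher, the gap being beyond the scatter. For the measured compounds named here, the single measured step, a number 43.6 percentage points lower from compound 1 to compound 2 (beyond the scatter), came from (4-methylphenyl)sulfonyl in place of hydrogen on an aromatic nitrogen. Compound 3 `O=C1COCCN1c1ccc(/N=C\c2cn(Cc3ccccc3)c3ccccc23)cc1` differs from compound 2 at that same place: benzyl in place of (4-methylphenyl)sulfonyl on an aromatic nitrogen. Going by the values given here, the one step that bears on this change is a number 43.6 percentage points lower from compound 1 to compound 2 (beyond the scatter), and it shows that the group on this aromatic nitrogen can move the number a long way. Nothing measured shows where benzyl falls between hydrogen and (4-methylphenyl)sulfonyl. Because a number 43.6 percentage points lower from compound 1 to compound 2 (beyond the scatter) was large, a step of middling size, upward, is expected for compound 3, namely a number 22.6 percentage points higher from compound 2 to compound 3 (beyond the scatter). Compound 3 is therefore estimated at 80% in this assay, with a range from 50% to 105%.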

Compound 3, a percentage reported as activity, at one concentration (the size of the read-out at that concentration, not a potency): 56.2%
The estimate for compound 3 lay 23.8 percentage points above the measured number; measured number inside the range.
By their numbers in this assay, from the lowest: compounds 3 and 2 (each within the scatter of the next); then compound 1.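

In this assay the change to benzyl gives a number 1.2 percentage points lower from compound 2 to compound 3 (within the scatter) and so separates (4-methylphenyl)sulfonyl from benzyl by nothing beyond the usual scatter, although benzyl has fewer heavy atoms and no hydrogen-bond acceptors. Measured against hydrogen, benzyl gives a number 44.8 percentage points lower from compound 1 to compound 3 (beyond the scatter) and so shows that the large drop is not tied to the sulfonyl-bearing group: in these three compounds, both groups on this aromatic nitrogen go with the lower number, and only hydrogen stands apart. No data given here explain this match between the two groups.

Going by these compounds, it remains open whether a much smaller group such as methyl would already give the lower number. Nor do these compounds show what a chain ending in an amine or a carboxylic acid would do at this place.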